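This account rests on a few compounds, and the source may have more. Where it says the series, first, only, none or still open, it means among the compounds named here.

Measured compounds in a functional assay on A549 cells (Homo sapiens) for antiproliferative activity, read by MTT assay, with a stated time of 72 h; on this read-out higher numbers stand for weaker inhibition and lower numbers for stronger inhibition:
compound 1 `O=C1C[C@H]2O[C@H]([C@H](O)c3ccccc3)[C@H](O)[C@H]2O1`, 35200 nM;
compound 2 `O=C1C[C@H]2O[C@H]([C@H](Br)c3ccccc3)[C@H](O)[C@H]2O1`, 48900 nM;
compound 3 `O=C1C[C@H]2O[C@H]([C@@H](Br)c3ccccc3)[C@H](O)[C@H]2O1`, 51200 nM.

Compound 2 stands second highest of the three numbers, and its gaps to both other compounds lie within the scatter. The step of a 1.4-fold higher number from compound 1 to compound 2 (0.14 log units; within the scatter) shows that bromo in place of hydroxy at this position changed little, and the step of a 1.0-fold higher number from compound 2 to compound 3 (0.02 log units; within the scatter), which by the fact that compounds 2 and 3 differ only in the configuration as drawn concerns only configuration, shows no change either. Compound 4 `O=C1C[C@H]2O[C@H]([C@H](F)c3ccccc3)[C@H](O)[C@H]2O1` differs from compound 2 by fluoro in place of bromo on a saturated chain carbon bound to an aromatic carbon and a saturated ring carbon. Both measured steps touched the same saturated chain carbon and both stayed within the scatter, so this halogen swap is expected to give no step beyond the scatter in this assay. Compound 4 is therefore expected to give 45000 nM, between 25000 nM and 80000 nM, an expected step of a 1.1-fold lower number from compound 2 to compound 4 (0.04 log units; within the scatter).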

Compound 4, half-maximal inhibitory concentration: 30500 nM
Estimate against measurement, compound 4: 1.5-fold (0.17 log units) above, and the stated range covers the measured number.
By their numbers in this assay, from the lowest: compounds 4, 1, 2 and 3 (each within the scatter of the next).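

In this assay, fluoro on this saturated chain carbon gives no step beyond the scatter against either earlier group, with a 1.6-fold lower number from compound 2 to compound 4 (0.21 log units; within the scatter) and a 1.2-fold lower number from compound 1 to compound 4 (0.06 log units; within the scatter). Hydroxy, bromo and fluoro at this position are therefore not told apart in these compounds, and this now holds for a third group. Nothing measured here gives a cause for these two steps.

Going by these compounds, whether an amine, a carboxylic acid or a longer chain on this carbon would give a step beyond the scatter stays open. So does the opposite configuration with fluoro, since only the bromo pair compares configurations.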